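From cyclopentyl to 5-cyanopentyl: the expected shift

A few compounds are considered here, and "the series" means these few. Any claim that something is new, unique, unknown or untested is made for them only; others in the source may bear on it.

The series shares one core. Compound 1 `Nc1ccnc(-c2nn(Cc3ccccc3F)c3ncccc23)n1` carries no substituent on the aromatic carbon in question, and in a functional assay (aorta) with Oryctolagus cuniculus as the target (on this read-out higher numbers stand for weaker inhibition and lower numbers for stronger inhibition), compound 1 gives 270 nM; 265000 nM (2 entries); the two entries lie far apart (the several entries of compound 1 in this assay, 270 nM; 265000 nM (2 entries)), so no single number can be set beside it. Compound 2 `CCCCCc1cnc(-c2nn(Cc3ccccc3F)c3ncccc23)nc1N` carries pentyl there, and in this assay compound 2 gives 200000 nM. Compound 3 `Nc1nc(-c2nn(Cc3ccccc3F)c3ncccc23)ncc1C1CCCC1` carries cyclopentyl instead, and in this assay compound 3 gives 904000 nM, the higher of the two single numbers; the step of a 4.5-fold higher number from compound 2 to compound 3 (0.66 log units; beyond the scatter) separates it from its nearest neighbour, compound 2.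

Compound 4 `N#CCCCCCc1cnc(-c2nn(Cc3ccccc3F)c3ncccc23)nc1N` is not yet measured. The change from compound 3: 5-cyanopentyl in place of cyclopentyl on an aromatic carbon. For the measured compounds named here, only one measured step bears on it. Because a 4.5-fold higher number from compound 2 to compound 3 (0.66 log units; beyond the scatter) shows the open chain of compound 2 at the lower number and the ring of compound 3 at the higher one, the step to compound 4, which again carries an open chain, is expected to run the other way, back towards the number of compound 2. For compound 4 the expected step is a 3.6-fold lower number from compound 3 to compound 4 (0.56 log units; beyond the scatter). For compound 4 the estimate in this assay is 250000 nM, with a range from 80000 nM to 800000 nM.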

Compound 4, half-maximal inhibitory concentration: 588000 nM
The estimate for compound 4 lay 2.4-fold (0.37 log units) below the measured number, and the stated range covers the measured number.
By their numbers in this assay, from the lowest: compound 2; then compounds 4 and 3 (each within the scatter of the next).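

In this assay an open chain at this position does not by itself bring the number back to that of compound 2: the step is a 1.5-fold lower number from compound 3 to compound 4 (0.19 log units; within the scatter) and leaves the 5-cyanopentyl chain and the cyclopentyl ring indistinguishable on this read-out. For the compounds shown here, the change at the chain end does register, though modestly: cyano on the pentyl chain gives a 2.9-fold higher number from compound 2 to compound 4 (0.47 log units; beyond the scatter) and so sets compound 4 apart from compound 2, which means that ring against chain is not the only change at this position that moves the number. No measurement shown gives a reason for either step.

From the compounds shown here alone, whether this shift belongs to the nitrile in particular stays open, and an amine, a hydroxyl or a carboxylic acid at the same chain end, or a longer plain alkyl chain, would separate the end group from the chain length. Compound 1, with hydrogen at this position, offers no single reference number for these comparisons, as its two entries lie far apart.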